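A few compounds are considered here, and "the series" means these few. Any claim that something is new, unique, unknown or untested is made for them only; others in the source may bear on it.

Of the compounds shown here, two with a shared core have been measured. Compound 1 `COc1ccc(-c2nc(C)c(C(=O)CSc3nc(N)c(C#N)c(-c4ccccc4)n3)s2)cc1` and compound 2 `Cc1nc(-c2ccc(Cl)cc2)sc1C(=O)CSc1nc(N)c(C#N)c(-c2ccc(Cl)cc2)n1` both carry a substituted six-membered ring on each side of the core. In a functional assay on U-87MG ATCC cells for antiproliferative activity against U-87 MG (Homo sapiens), read by MTT assay, with a stated time of 48 h, tested at 5 uM (on this read-out lower numbers stand for a stronger effect and higher numbers for a weaker effect at the one concentration tested), compound 1 gives 61.8%. In this assay compound 2 gives 46.1%, the lowest of the two numbers, with compound 1 higher by a margin beyond the scatter. Compound 3 `Cc1nc(-c2ccc(Cl)cc2)sc1C(=O)CSc1nc(N)c(C#N)c(-c2ccccc2)n1` differs from compound 2 in one place: hydrogen in place of chloro on an aromatic carbon. Cut one bond further out, the change reads 4-chlorophenyl to phenyl. For the measured compounds named here, no single-change step between measured compounds is available to guide the size of this change. Compound 3 is expected to give 52%, with a range of 38% to 66%. The step of a number 5.9 percentage points higher from compound 2 to compound 3 (within the scatter) is expected to stay within the usual scatter.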

Compound 3, a percentage reported as activity, at one concentration (the size of the read-out at that concentration, not a potency): 71.1%
Compound 3: the middle estimate sits 19.1 percentage points below what was measured; the whole stated range lies below it.
By their numbers in this assay, from the lowest: compound 2; then compounds 1 and 3 (each within the scatter of the next).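

In this assay, the chloro para to a large group proves to matter at the one concentration tested: hydrogen in its place gives a number 25 percentage points higher from compound 2 to compound 3 (beyond the scatter), a weaker effect. Chloro in place of methoxy on an aromatic carbon gives a number 9.3 percentage points higher from compound 1 to compound 3 (within the scatter), so that change shows no clear effect. Nothing available explains why the chloro matters here.

Going by these compounds, whether bromo, methyl or an amine at this position would keep the effect of the chloro stays open, as does whether the step holds at other concentrations.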